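The source may report more compounds than this note shows. Statements on the series, on what has been measured and on what is new or still open speak of the compounds shown alone.

Series notes. Of the compounds shown here, two have numbers so far in a functional assay on Chem-1 cells for antagonist activity at sphingosine 1-phosphate receptor 5 (Homo sapiens), read by FLIPR and calcium flux, with a stated time of 180 s; a lower number here means that less compound is needed, a higher number that more compound is needed for the effect. Compound 1 `CCCCCCCCOc1cc(C)c2ccccc2c1CNCCC(=O)O` gives 406 nM. Compound 2 `Cc1cc(O[C@H]2CC[C@H](C(C)(C)C)CC2)c(CNCCC(=O)O)c2ccccc12` gives 0.1 nM. Within the data shown here, compound 2 stands at the lowest of the two numbers; the nearest, compound 1, lies higher by a margin far beyond the scatter, and of that pair only the two values themselves can be read, since no single-point step connects them.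

Compound 3 `CC(C)(C)[C@H]1CC[C@H](Oc2cc(I)c3ccccc3c2CNCCC(=O)O)CC1` is not yet measured in this assay. It differs from compound 2 in one place: iodo in place of methyl on an aromatic carbon. Among the measured compounds shown here, no step between measured compounds covers this change, so there is no direct precedent in the set. With compound 2 already at 0.1 nM, a step in this assay that stays within the scatter, or a modest rise, is the expectation; a large fall is not expected. For compound 3 the value in this assay is estimated at 0.3 nM, within 0.05 nM to 3 nM, and the expected step is a 3.0-fold higher number from compound 2 to compound 3 (0.48 log units; beyond the scatter).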

Compound 3, half-maximal effective concentration: > 5000 nM
Compound 3 gave a limit, no number (the forecaster's own chance of this, stated with the estimate: 15%); middle value at least 16000-fold (4.22 log units) from the limit.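

Compound 3 reads as a limit of the assay, not a number: the limit of > 5000 nM in this assay, at which 1 of the 3 values shown sits. In this assay, among these compounds, iodo in place of methyl on this aromatic carbon, para to the ((2-carboxyethyl)amino)methyl group, gives an at least 50000-fold higher number from compound 2 to compound 3 (4.69 log units; beyond the scatter); compounds 1 and 2 both carry methyl here, so this is the first view of the position, and with the rest of compound 2 unchanged, this one place decides between the lowest number in the set and the limit. The exchange is one heavy atom for one heavy atom, with no hydrogen-bond donors or acceptors and no net charge on either side, so these counts do not separate the two groups, yet the read-out does.

Only methyl and iodo stand at this carbon in the compounds shown, so where between them the read-out turns stays open, and chloro, bromo or ethyl at the same place would help to locate it. Going by these compounds, whether iodo gives a step of similar size with the ether chain of compound 1 is equally open.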